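Swapping a hydroxyphenyl for an ethylphenyl on the sulfonamide

A few compounds are considered here, and "the series" means these few. Any claim that something is new, unique, unknown or untested is made for them only; others in the source may bear on it.

Compound 1, `O=S(=O)(Nc1ccc2oc(-c3ccccc3)nc2c1)c1ccccc1O`: 33000 nM
Compound 2, `O=S(=O)(Nc1ccc(-c2nc3ccccc3o2)cc1)c1ccc(C(F)(F)F)cc1`: 94000 nM
Compound 3, `O=S(=O)(Nc1ccc(-c2nc3ccccc3o2)cc1)c1ccccc1Cl`: reported only as a limit, > 100000 nM

All three compounds carry a sulfonamide on a shared core and differ in the ring attached to the sulfonyl sulfur. In an ADME assay on HEK293 cells (Homo sapiens) for cytotoxicity, read by resazurin assay, with a stated time of 48 h (on this read-out higher numbers stand for lower toxicity in this test and lower numbers for higher toxicity in this test), compound 1 gives 33000 nM, the lowest of the two numbers available, meaning the strongest toxicity in this test among them. Compound 2 gives 94000 nM, a higher number that lies beyond the usual scatter. For compound 3 this assay reports no number but a limit, > 100000 nM. That is the limit of > 100000 nM in this assay, at which 1 of the 3 values shown sits.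

Compound 4, `CCc1ccc(S(=O)(=O)Nc2ccc3oc(-c4ccccc4)nc3c2)cc1`, has not yet been measured. It differs from compound 1 in one place: 4-ethylphenyl in place of 2-hydroxyphenyl on a sulfonyl sulfur. Going by the values given here, no pair of measured compounds shows this same change, so its size cannot be read from the data. The expected step is modest and toward a higher number, a 1.7-fold higher number from compound 1 to compound 4 (0.22 log units; within the scatter). Compound 4 is therefore estimated at 55000 nM, with a range of 20000 nM to 150000 nM, and a fair chance that only a limit is reported.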

Compound 4, half-maximal cytotoxic concentration: 81000 nM
The estimate for compound 4 lay 1.5-fold (0.17 log units) below the measured number, and the stated range covers the measured number.
By their numbers in this assay, from the lowest: compound 1; then compounds 4 and 2 (each within the scatter of the next). At a limit, above all of these: compound 3.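

In this assay, 4-ethylphenyl in place of 2-hydroxyphenyl on a sulfonyl sulfur gives a 2.5-fold higher number from compound 1 to compound 4 (0.39 log units; beyond the scatter) and so lower toxicity in this test. Going by these compounds alone, the earlier compounds offered no comparison of two compounds differing in one place, so this is the first direct reading of what a change at this position does on the shared core. The swap removes a hydrogen-bond donor and a hydrogen-bond acceptor and adds carbon, but no measurement shown says which part of the change matters for this step.

A single step cannot separate losing the hydroxyl from gaining the ethyl. As far as these compounds go, how a plain phenyl, or a ring carrying an amine or a carboxylic acid, would behave at this position on the same core remains open.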